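Chloro for cyano on the anilide ring of compound 3

The source may hold more compounds than are shown below. What is called first, only, known or untested is meant among the compounds shown, and "the series" means these compounds.

Working notes on a small anilide series measured in an ADME assay for permeability, using PAMPA; on this read-out higher numbers stand for higher permeability and lower numbers for lower permeability. Compound 1 `O=C(Nc1ccc([N+](=O)[O-])cc1Cl)c1cccc2cc[nH]c12` gives 1760 10^-6 cm/s in this assay. Compound 2 `COc1cc([N+](=O)[O-])ccc1NC(=O)c1cc(Cl)ccc1O` gives 334 10^-6 cm/s. Compound 3 `N#Cc1ccc(NC(=O)c2cc(Cl)ccc2O)c(Cl)c1` gives 5.1 10^-6 cm/s and so stands lowest of the three numbers; compound 2 gives the nearest number and compound 1 the furthest, both of them higher by gaps that lie beyond the scatter of repeated measurements. Going by the values given here, no pair of these three differs in one place only, so no single-change step among measured compounds is available.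

The next compound, compound 4 `O=C(Nc1ccc(Cl)cc1Cl)c1cc(Cl)ccc1O`, differs from compound 3 in one place: chloro in place of cyano on an aromatic carbon. The cyano group that leaves carries the only hydrogen-bond acceptor of that position; the chloro group that enters carries none, and the count of heavy atoms falls by one.

The step of a 12-fold higher number from compound 3 to compound 4 (1.07 log units; beyond the scatter) is expected to run upward, beyond the scatter, given that compound 3 starts from the lowest number of the set. Among the compounds with values here, for compound 4 the expected value in this assay is 60 10^-6 cm/s, with a plausible range from 10 10^-6 cm/s to 400 10^-6 cm/s; the width of the range reflects that no measured step covers this exact change.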

Compound 4, apparent permeability in the ADME assay: < 22.4 10^-6 cm/s
Compound 4 ended at the assay's limit; the forecaster's own chance of this, stated with the estimate: 5%; middle value at least 2.6-fold (0.42 log units) from the limit.
By their numbers in the ADME assay, from the lowest: compound 3; then compound 2; then compound 1.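

In the ADME assay compound 4 gives < 22.4 10^-6 cm/s and this is a limit of the assay and not a number. In a physicochemical assay for solubility (on this read-out higher numbers stand for higher solubility and lower numbers for lower solubility), compound 3 gives < 1 ug/mL and this is a limit of the assay and not a number. In the physicochemical assay compound 4 gives < 1 ug/mL and this is also a limit of the assay and not a number. The step between these two compounds cannot be read in either assay. On these data alone, how far chloro in place of cyano on an aromatic carbon moves either read-out stays open.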